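Chain shortening on the core of compound 1

This account rests on a few compounds, and the source may have more. Where it says the series, first, only, none or still open, it means among the compounds named here.

Values in a functional assay on HepG2 cells (Homo sapiens) for inhibition, read by MTT assay, with a stated time of 72 h; a higher number here means a weaker inhibitor, a lower number a stronger inhibitor:
- compound 1 `Nc1ncnc2c1c(-c1cnc3[nH]ccc3c1)nn2CCCCCCCCC(=O)NO`: 3050 nM
- compound 2 `Nc1nc2cc(-c3nn(CCCCCCCCC(=O)NO)c4ncnc(N)c34)ccc2o1`: 2610 nM
- compound 3 `Nc1nc2cc(-c3nn(CC(=O)NO)c4ncnc(N)c34)ccc2o1`: > 150000 nM (a limit, not a number)
- compound 4 `Nc1ncnc2c1c(-c1cnc3[nH]ccc3c1)nn2CCCC(=O)NO`: not yet measured

Among the measured compounds shown here, compound 1 stands level with its one numeric neighbour (a 1.2-fold lower number from compound 1 to compound 2 (0.07 log units; within the scatter)), a step that stays within the scatter. The change to compound 4 is hydroxycarbamoyl in place of 5-(hydroxycarbamoyl)pentyl on a saturated chain carbon, three bonds along the chain from an aromatic nitrogen. For the measured compounds named here, no measured step alters the chain alone. Going by the values given here, the only guide is the core of compound 2, which gives 2610 nM in this assay with its long chain. Compound 3, on that core, is reported only as a limit (> 150000 nM). A large rise in the number is therefore expected (a 13-fold higher number from compound 1 to compound 4 (1.12 log units; beyond the scatter)) in this assay. The estimate for compound 4 is 40000 nM (expected range 9000 nM to 150000 nM).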

Compound 4, half-maximal inhibitory concentration: > 50000 nM
Compound 4: a limit, no number; the forecaster's own chance of this, stated with the estimate: 30%; at least 1.2-fold (0.09 log units) between middle value and limit.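

In this assay, hydroxycarbamoyl in place of 5-(hydroxycarbamoyl)pentyl on a saturated chain carbon, three bonds along the chain from an aromatic nitrogen, gives an at least 16-fold higher number from compound 1 to compound 4 (1.21 log units; beyond the scatter). This is the only step shown that alters the chain alone, and shortening it with the core unchanged is enough for a large change in this position. Compound 4 is reported as a limit, not a number, so the full size of the step stays unknown: the limit of > 50000 nM in this assay, at which 1 of the 4 values shown sits.

Still open, going by these compounds, is how the number moves with chains of intermediate length, or with a chain longer than 6-(hydroxycarbamoyl)hexyl. Also open, on these data alone, is what a carboxylic acid in place of the hydroxycarbamoyl end would give on the long chain.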